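This account rests on a few compounds, and the source may have more. Where it says the series, first, only, none or still open, it means among the compounds named here.

Of the compounds shown here, three with a shared core have been measured so far in a functional assay on MDA-MB-468 cells (Homo sapiens) for antiproliferative activity, read by MTT assay, with a stated time of 72 h (a higher number here means a weaker inhibitor, a lower number a stronger inhibitor), and they differ in a single group on an aromatic ring. Compound 3 (`COc1ccc(-n2ccnc2-c2cc(OC)c(OC)c(OC)c2)cc1N`) carries an amino group there and gives 90 nM in this assay, which places it level with the nitro compound. That nitro compound, compound 1 (`COc1ccc(-n2ccnc2-c2cc(OC)c(OC)c(OC)c2)cc1[N+](=O)[O-]`), gives 100 nM in the same test. Compound 2 (`COc1ccc(-n2ccnc2-c2cc(OC)c(OC)c(OC)c2)cc1`) has only hydrogen at that place and gives 500 nM as the one clearly weaker result.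

The next compound is compound 4 (`COc1ccc(-n2ccnc2-c2cc(OC)c(OC)c(OC)c2)cc1O`), where the change is hydroxy in place of amino on an aromatic carbon and, in words, hydroxy in place of amino on an aromatic carbon. Among the measured compounds shown here, no measured step makes this exact swap, so the evidence is indirect. Putting an amino group in place of hydrogen gave a 5.6-fold lower number from compound 2 to compound 3 (0.74 log units; beyond the scatter) as a modest gain, while replacing nitro with hydrogen gave a 5.0-fold higher number from compound 1 to compound 2 (0.70 log units; beyond the scatter) as a modest loss. Swapping nitro for amino gave a 1.1-fold lower number from compound 1 to compound 3 (0.05 log units; within the scatter) with no real change. Among these compounds, then, the two groups tested both beat hydrogen and match each other, so hydroxy is expected to behave similarly. The estimated step is a 1.1-fold lower number from compound 3 to compound 4 (0.05 log units; within the scatter) at its middle, meaning that no change beyond the scatter is expected. For compound 4 the estimated value is 80 nM with an expected range from 25 nM to 300 nM in repeat measurements.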

Compound 4, half-maximal inhibitory concentration: 300 nM
The estimate for compound 4 lay 3.8-fold (0.57 log units) below the measured number; measured number inside the range.
By their numbers in this assay, from the lowest: compounds 3 and 1 (each within the scatter of the next); then compounds 4 and 2 (each within the scatter of the next).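

In this assay, among the compounds shown here, this position separates groups that looked interchangeable among the earlier compounds: hydroxy in place of amino gives a 3.3-fold higher number from compound 3 to compound 4 (0.52 log units; beyond the scatter), and hydroxy in place of nitro gives a 3.0-fold higher number from compound 1 to compound 4 (0.48 log units; beyond the scatter), whereas hydroxy in place of hydrogen gives only a 1.7-fold lower number from compound 2 to compound 4 (0.22 log units; within the scatter). The gain over hydrogen seen with amino and nitro therefore does not extend to every group placed here, and amino and hydroxy differ in this way even though both are a single heavy atom with matching computed counts of hydrogen-bond donors and acceptors, so those counts alone do not predict the result. Nothing available here offers a measured reason for the difference between amino and hydroxy.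

The two groups that match each other here both carry nitrogen, but two examples cannot show whether that link is real, and a methylamino group, an acetamido group or a nitrile at this place would test it. A methoxy group in place of the hydroxy would show whether replacing the hydroxy hydrogen with a methyl group changes the result, and the compounds shown leave that open as well.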